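A few compounds are considered here, and "the series" means these few. Any claim that something is new, unique, unknown or untested is made for them only; others in the source may bear on it.

Of the compounds shown here, two have so far been read in a physicochemical assay for solubility, read by nephelometry, measured as kinetic solubility; a lower number here means a less soluble compound, a higher number a more soluble compound. Compound 1 (`Cc1ccc(-c2cc(C(=O)Nc3cccnc3)c3cc(F)ccc3n2)cc1`) gives 36000 nM. Compound 2 (`O=C(NCCN1CCCC1)c1cc(-c2ccc(S(=O)(=O)N3CCOCC3)cc2)nc2ccc(F)cc12`) gives 109000 nM, which is the higher of the two numbers, and its gap to compound 1 lies beyond the usual scatter. For the measured compounds named here, these two compounds are the only measured reference points, and the data hold no measured step that changes a single place in the structure.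

The next compound to be read is compound 3 (`O=C(NCCN1CCCC1)c1cc(-c2ccc(CN3CCCC3=O)cc2)nc2ccc(F)cc12`). It has (2-oxopyrrolidin-1-yl)methyl in place of (morpholin-4-yl)sulfonyl on an aromatic carbon of compound 2, para to a large group: (2-oxopyrrolidin-1-yl)methyl in place of (morpholin-4-yl)sulfonyl on an aromatic carbon. The rest of the structure stays the same.

Going by the values given here, with no measured precedent for this exchange, the expectation starts from compound 2 at 109000 nM, and no change beyond the scatter is expected in this assay. As far as these compounds go, the direction of any small shift remains open, although a slightly lower number is assumed. The estimated step is a 1.1-fold lower number from compound 2 to compound 3 (0.04 log units; within the scatter). For compound 3 the estimated value is 100000 nM, with an expected range from 45000 nM to 180000 nM.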

Compound 3, solubility: > 217000 nM
Compound 3 was reported as a limit; the forecaster's own chance of this, stated with the estimate: 15%; middle value at least 2.1-fold (0.33 log units) away from the limit.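

For the compounds shown here, the exchange of (morpholin-4-yl)sulfonyl for (2-oxopyrrolidin-1-yl)methyl on this aromatic carbon, para to a large group, gives the first single-place step: an at least 1.9-fold higher number from compound 2 to compound 3 (0.29 log units; that floor lies within the scatter). In this assay compound 3 is reported as a limit, > 217000 nM, and not as a number. The result shows that (morpholin-4-yl)sulfonyl can leave this place with no drop in the reading, although the true distance between the two compounds cannot be read, because the reading of compound 3 stops at the limit: the limit of > 217000 nM in this assay, at which 1 of the 3 values shown sits.

The compounds shown leave open whether the same reading would follow from a (morpholin-4-yl)methyl group, which would keep the six-membered ring while losing the sulfonyl, or from an open-chain amide or a carboxylic acid at this place. Going by these compounds alone, they also leave open whether the exchange would read the same on a different amide side chain, such as the one in compound 1, which differs from compound 2 in more than one place.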